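Removing a Chloro Group from a Sulfonamide Aryl Amide

A few compounds are considered here, and "the series" means these few. Any claim that something is new, unique, unknown or untested is made for them only; others in the source may bear on it.

Measured compounds:
compound 1, `O=C(Nc1ccc(S(=O)(=O)Nc2ccccc2)cc1)c1cc(F)c(Cl)cc1F`, 141 nM
compound 2, `O=C(Nc1ccc(S(=O)(=O)Nc2cccc(Cl)c2)cc1)c1ccc(Cl)cc1Cl`, 575 nM

Of the compounds shown here, two have been measured in a functional assay on HEK293 cells for agonist activity at probable G-protein coupled receptor 27 (Homo sapiens), read by a luciferase reporter and beta-arrestin recruitment, with a stated time of 10 min; a higher number here means that more compound is needed for the effect, a lower number that less compound is needed. Compound 1 gives 141 nM, and compound 2 gives 575 nM, the higher of the two numbers; the gap between them lies beyond the scatter. These two compounds differ in more than one place, so nothing is said here about any single change between them.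

Compound 3, `O=C(Nc1ccc(S(=O)(=O)Nc2ccccc2)cc1)c1ccc(Cl)cc1Cl`, has not yet been measured. It differs from compound 2 by hydrogen in place of chloro on an aromatic carbon, which cut one bond further out reads 3-chlorophenyl to phenyl. Among the measured compounds shown here, with no single-change step available between measured compounds, the direction is uncertain; a small step toward a lower number, or none beyond the scatter, is expected. Compound 3 is estimated at 350 nM, in a range from 120 nM to 1000 nM, which means an expected step of a 1.6-fold lower number from compound 2 to compound 3 (0.22 log units; within the scatter).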

Compound 3, half-maximal effective concentration: 457 nM
The estimate for compound 3 lay 1.3-fold (0.12 log units) below the measured number, and the stated range covers the measured number.
By their numbers in this assay, from the lowest: compound 1; then compounds 3 and 2 (each within the scatter of the next).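

In this assay, replacing 3-chlorophenyl with phenyl gives a 1.3-fold lower number from compound 2 to compound 3 (0.10 log units; within the scatter), so with the 2,4-dichlorophenyl amide held constant, this chloro makes no difference that can be told from the scatter. Among the compounds shown here, compound 3 also gives the first single-place comparison with compound 1, and 2,4-dichlorophenyl in place of 4-chloro-2,5-difluorophenyl on the carbonyl carbon gives a 3.2-fold higher number from compound 1 to compound 3 (0.51 log units; beyond the scatter), a step that, unlike the chloro step, lies beyond the scatter. No measurement shown here offers an explanation for either step.

The compounds shown leave open whether a methoxy group or an amine on that same aromatic carbon would also leave the number within the scatter. They also leave open whether the chloro step would stay as small alongside the 4-chloro-2,5-difluorophenyl amide, and which halogen on that group accounts for the larger step.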